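Swapping the aryl group on the imidazole of a quinoline ether

This account rests on a few compounds, and the source may have more. Where it says the series, first, only, none or still open, it means among the compounds named here.

Measured compounds:
compound 1 `COc1cc2c(Oc3ccc(NC(=O)c4cn(-c5cc(C)ccc5C)cn4)cc3F)ccnc2cc1OCCCN1CCN(C)CC1` gives 470 nM
compound 2 `COc1cc2c(Oc3ccc(NC(=O)c4cn(-c5ccccc5OC(F)(F)F)cn4)cc3F)ccnc2cc1OCCCN1CCC(C)CC1` gives 690 nM

Both compounds were tested in a functional assay on HT-29 cells (Homo sapiens) for cytotoxicity, read by MTT assay, with a stated time of 72 h; a lower number here means a stronger inhibitor, a higher number a weaker inhibitor. Compound 1 and compound 2 share the same core and differ in two places at once: the aryl group on the five-membered ring and the amine at the end of the three-carbon chain. The two numbers lie within the usual scatter of each other, so neither compound can be called the stronger inhibitor on this evidence; compound 2 simply stands alongside compound 1.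

Compound 3 `COc1cc2c(Oc3ccc(NC(=O)c4cn(-c5cc(C)ccc5C)cn4)cc3F)ccnc2cc1OCCCN1CCC(C)CC1` has not been measured yet. It differs from compound 2 by a single change: 2,5-dimethylphenyl in place of 2-(trifluoromethoxy)phenyl on an aromatic nitrogen. This brings the aryl group of compound 1 onto the amine tail of compound 2. Since compound 1 and compound 2 sit close together in this assay, the step is expected to be small. The expected step from compound 2 to compound 3 is a 1.4-fold lower number from compound 2 to compound 3 (0.14 log units; within the scatter), a change not clearly beyond the scatter. Compound 3 is therefore estimated at 500 nM, with a plausible range from 200 nM to 1500 nM.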

Compound 3, half-maximal inhibitory concentration: 2220 nM
For compound 3 the middle estimate is 4.4-fold (0.65 log units) below the measured one; the whole stated range lies below it.
By their numbers in this assay, from the lowest: compounds 1 and 2 (each within the scatter of the next); then compound 3.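

In this assay, putting 2,5-dimethylphenyl in place of 2-(trifluoromethoxy)phenyl on the aromatic nitrogen gives a 3.2-fold higher number from compound 2 to compound 3 (0.51 log units; beyond the scatter) with the 4-methylpiperidin-1-yl tail held constant, so the choice of aryl group at this position does change the result. The tail also counts once 2,5-dimethylphenyl is held constant: 4-methylpiperidin-1-yl in place of 4-methylpiperazin-1-yl gives a 4.7-fold higher number from compound 1 to compound 3 (0.67 log units; beyond the scatter) in the same assay. For the compounds shown here, these are the first single-change comparisons, and both are modest in size, lie beyond the scatter and end at compound 3, which carries both the 2,5-dimethylphenyl group and the 4-methylpiperidin-1-yl tail.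

The compounds shown leave open whether the aryl swap would have the same size with the 4-methylpiperazin-1-yl tail, and how a plain phenyl group, a 2-methoxyphenyl group or a morpholine tail would compare. Nothing measured alongside these numbers offers an explanation for either step.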